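The compounds below may be only part of what the source reports. "The series", "measured", "known", "first", "only" and "open" are said of these compounds alone.

In a functional assay on MT4 cells (Homo sapiens) for cytotoxicity, read by MTT assay (a higher number here means that more compound is tolerated, a lower number that less compound is tolerated), compound 1 `Cc1c(O)nc(S(=O)(=O)Cc2ccc([N+](=O)[O-])cc2)nc1Cc1c(Cl)cccc1Cl` reaches only a limit of the measurement, at > 53000 nM. Compound 2 `COc1ccc(CS(=O)(=O)c2nc(O)c(C)c(Cc3c(Cl)cccc3Cl)n2)cc1` gives 2800 nM in this assay. The two differ by methoxy in place of nitro on an aromatic carbon, and this change makes the step of an at least 18-fold lower number from compound 1 to compound 2 (1.27 log units; beyond the scatter), read from the limit (the limit of > 53000 nM in this assay, at which 1 of the 3 values shown sits). Compound 3 `Cc1c(O)nc(SCc2ccc([N+](=O)[O-])cc2)nc1Cc1ccc(F)cc1` likewise reaches only a limit in this assay, at > 65000 nM, which is the limit of > 65000 nM in this assay, at which 1 of the 3 values shown sits. The difference between the core of compound 3 and the core of compound 1 is not broken down here. Compound 4 `COc1ccc(CSc2nc(O)c(C)c(Cc3ccc(F)cc3)n2)cc1` has not yet been measured in this assay and differs from compound 3 by methoxy in place of nitro on an aromatic carbon, the same change as between compound 1 and compound 2. Compound 4 is therefore expected to show a step of about an at least 10-fold lower number from compound 3 to compound 4 (1.03 log units; beyond the scatter), resting on the measured step of an at least 18-fold lower number from compound 1 to compound 2 (1.27 log units; beyond the scatter). Compound 4 is estimated at 6000 nM, between 1500 nM and 60000 nM.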

Compound 4, half-maximal cytotoxic concentration: 8900 nM
The estimate for compound 4 lay 1.5-fold (0.17 log units) below the measured number, within the range that was stated.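

Putting 4-methoxyphenyl in place of 4-nitrophenyl again lowers the number in this assay, giving an at least 7.3-fold lower number from compound 3 to compound 4 (0.86 log units; beyond the scatter), so the direction of the step holds on both the core of compound 1 and the core of compound 3. On these data alone, both steps start from a limit of the assay, so their true sizes remain unknown and no constant size can be claimed for the change: the same change on two cores in this assay, an at least 18-fold lower number (1.27 log units; beyond the scatter) from compound 1 to compound 2 and an at least 7.3-fold lower number (0.86 log units; beyond the scatter) from compound 3 to compound 4; the limit leaves it open whether they differ These two pairs show the direction on two cores only and say nothing about any further core.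

The compounds shown leave open how an amine or a carboxylic acid would compare in the same place on the aromatic ring. They also leave open whether an ethoxy group or a longer chain would follow methoxy.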